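Removing one chloro group on two spiro peroxide cores

A few compounds are considered here, and "the series" means these few. Any claim that something is new, unique, unknown or untested is made for them only; others in the source may bear on it.

In a functional assay on L02 cells (Homo sapiens) for inhibition, read by MTT assay, with a stated time of 72 h (a higher number here means a weaker inhibitor, a lower number a stronger inhibitor), three compounds have been measured:

compound 1 `C=C(c1ccc(Cl)c(Cl)c1Cl)C1COC2(CCCC2)OO1`: 1190 nM
compound 2 `C=C(c1ccc(Cl)cc1Cl)C1COC2(CCCC2)OO1`: 2550 nM
compound 3 `C=C(c1ccc(Cl)c(Cl)c1Cl)C1COC2(CCCCC2)OO1`: 1220 nM

Compound 1 and compound 2 share one core and differ in a single place, (hydrogen in place of chloro on an aromatic carbon). That change produced a 2.1-fold higher number from compound 1 to compound 2 (0.33 log units; beyond the scatter) in this assay. Compound 3 carries the same three chloro groups on its aromatic ring as compound 1 but sits on a different core; the difference between the two cores is not broken down here. In this assay compound 3 and compound 1 give numbers that lie within the usual scatter of each other, so the data do not separate them.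

Compound 4 `C=C(c1ccc(Cl)cc1Cl)C1COC2(CCCCC2)OO1` has not yet been measured. It stands to compound 3 as compound 2 stands to compound 1: the change is hydrogen in place of chloro on an aromatic carbon, and the surroundings of the place are described in the same words in both cases, so this is the same change made on the second core. Among the compounds with values here, the one measured example of it is the step from compound 1 to compound 2, and since compound 3 and compound 1 give numbers within the scatter of each other, the expectation is that compound 4 will show a step of about the same size, namely an expected 2.1-fold higher number from compound 3 to compound 4 (0.33 log units; beyond the scatter). On that basis compound 4 is expected to give 2600 nM in this assay, with an expected range from 1500 nM to 4600 nM.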

Compound 4, half-maximal inhibitory concentration: 3690 nM
Beside the measured number, compound 4's estimate is 1.4-fold (0.15 log units) below it; measured number inside the range.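

In this assay, hydrogen in place of chloro on an aromatic carbon gave a 3.0-fold higher number from compound 3 to compound 4 (0.48 log units; beyond the scatter), so the number rises on the core of compound 3 as it did on the core of compound 1. Within the data shown here, the two steps point the same way, and their sizes cannot be told apart, so on these two cores the change carries over as a single step of about the same size: the same change on two cores in this assay, a 2.1-fold higher number (0.33 log units; beyond the scatter) from compound 1 to compound 2 and a 3.0-fold higher number (0.48 log units; beyond the scatter) from compound 3 to compound 4, 1.4-fold (0.15 log units) apart, within the scatter of two such steps This rests on only two matched pairs and one place on the aromatic ring, so it does not show that the change would carry over to any other core, and it says nothing about why the number rises when this chloro group leaves.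

The compounds shown hold only chloro or hydrogen at this place, so it remains open how a fluoro, a methyl or a methoxy group there would compare on either core. Also open, on these data alone, is what would follow from taking away either of the other two chloro groups instead, or from putting an amine or a carboxylic acid on the aromatic ring.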